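From 2-methylphenyl to 4-fluorophenyl: working notes

This account rests on a few compounds, and the source may have more. Where it says the series, first, only, none or still open, it means among the compounds named here.

Measured so far in a physicochemical assay for lipophilicity; a higher number here means a more lipophilic compound, a lower number a more polar compound
compound 1 `C[C@H]1CC[C@@H]2[C@@H](OC(=O)[C@]23CC(c2ccccc2)=NO3)[C@]2(C)C(=O)C=C[C@@]12O` gives 1.41
compound 2 `Cc1ccccc1C1=NO[C@]2(C1)C(=O)O[C@@H]1[C@H]2CC[C@H](C)[C@]2(O)C=CC(=O)[C@@]12C` gives 1.86

Compound 2 stands highest of the two (1.86), with compound 1 nearest and lower.

The next change leads to compound 3 `C[C@H]1CC[C@@H]2[C@@H](OC(=O)[C@]23CC(c2ccc(F)cc2)=NO3)[C@]2(C)C(=O)C=C[C@@]12O` and is 4-fluorophenyl in place of 2-methylphenyl on a carbon with a double bond to nitrogen with 4-fluorophenyl in place of 2-methylphenyl on a carbon with a double bond to nitrogen.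

Within the data shown here, the one measured step that bears on it is a number 0.45 log units higher from compound 1 to compound 2 (beyond the scatter) with methyl in place of hydrogen on an aromatic carbon. Among the measured compounds shown here, the methyl of compound 2 leaves in this change, and no measured step covers the fluorine.

A lower number is expected, with a number 0.31 log units lower from compound 2 to compound 3 (beyond the scatter) as the estimated step in this assay on this single measured step. Compound 3 is estimated at 1.55 within a range of 1.3 to 1.8 on present data.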

Compound 3, partition coefficient: 1.58
Compound 3: middle estimate off by 0.03 log units, on the low side; the measured number falls inside the stated range.
By their numbers in this assay, from the lowest: compounds 1, 3 and 2 (each within the scatter of the next, the first and the last beyond it).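

Fluoro in place of hydrogen on the aromatic carbon gives in this assay a number 0.17 log units higher from compound 1 to compound 3 (within the scatter) and so adds a reading for a group other than methyl on this phenyl ring. Among these compounds, the exchange of 2-methylphenyl for 4-fluorophenyl gives a number 0.28 log units lower from compound 2 to compound 3 (within the scatter) and leaves compound 3 not separable from either of the other two compounds, while the methyl step remains a number 0.45 log units higher from compound 1 to compound 2 (beyond the scatter) and stays the only step here that is beyond the scatter. Nothing on hand gives a reason for any of these steps.

The two groups on the phenyl ring differ in kind and in place, so the series does not yet show how far the methyl and the fluoro readings carry to other substituents. From the compounds shown here alone, how this assay reads with an amine or a carboxylic acid on the same ring remains open, as does a longer chain in place of the methyl.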